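A Chlorobenzyl Group Replaces 4-Methoxyphenyl on the Nitrogen

This account rests on a few compounds, and the source may have more. Where it says the series, first, only, none or still open, it means among the compounds named here.

Measured in a functional assay on HepG2 cells (Homo sapiens) for antiproliferative activity, read by MTT assay, with a stated time of 48 h; a higher number here means a weaker inhibitor, a lower number a stronger inhibitor:
- Compound 1 `Cc1ccc(-c2ccc3c(c2)C(=O)C(=O)N3)cc1`: 6000 nM
- Compound 2 `CCN1C(=O)C(=O)c2cc(-c3ccc(OC)cc3)ccc21`: 4470 nM
- Compound 3 `COc1ccc(-c2ccc3c(c2)C(=O)C(=O)N3c2ccc(OC)cc2)cc1`: > 10000 nM, a limit and not a number

Compound 3 stands at the limit of > 10000 nM in this assay, at which 1 of the 3 values shown sits, so it offers a limit and no number to start from.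

Compound 4 `COc1ccc(-c2ccc3c(c2)C(=O)C(=O)N3Cc2cccc(Cl)c2)cc1` keeps the shared core of compound 3 and the 4-methoxyphenyl on that core that compound 2 also carries. It differs from compound 3 at one place, with 3-chlorobenzyl in place of 4-methoxyphenyl on an amide-type nitrogen in a ring.

For the measured compounds named here, one measured step bears directly on this nitrogen. It is an at least 2.2-fold higher number from compound 2 to compound 3 (0.34 log units; beyond the scatter), with 4-methoxyphenyl in place of ethyl, so the group that compound 4 gives up is the one that came with the higher number. Compound 2, with ethyl at this nitrogen, gives 4470 nM. Going by the values given here, no measured compound carries 3-chlorobenzyl, so the size of the change remains uncertain.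

Expected in this assay is a step of an at least 6.6-fold lower number from compound 3 to compound 4 (0.82 log units; beyond the scatter), towards a stronger inhibitor. Compound 4 is estimated at 1500 nM, with an expected range of 200 nM to 7000 nM.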

Compound 4, half-maximal inhibitory concentration: 320 nM
The estimate for compound 4 lay 4.7-fold (0.67 log units) above the measured number, within the range that was stated.
By their numbers in this assay, from the lowest: compound 4; then compounds 2 and 1 (each within the scatter of the next). At a limit, above all of these: compound 3.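

In this assay, the amide-type nitrogen in the ring can carry a group holding a six-membered aromatic ring and still give the lowest number shown, which compound 3 alone could not suggest. Placing 3-chlorobenzyl there in place of 4-methoxyphenyl gives an at least 31-fold lower number from compound 3 to compound 4 (1.49 log units; beyond the scatter), although both groups have 8 heavy atoms and one six-membered aromatic ring, so the ring's presence at this nitrogen does not by itself set the number. The step of a 14-fold lower number from compound 2 to compound 4 (1.15 log units; beyond the scatter) shows that 3-chlorobenzyl also outdoes ethyl at this nitrogen, while the other step gives only a minimum size: the limit of > 10000 nM in this assay, at which 1 of the 4 values shown sits.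

The compounds shown leave open whether the chlorine or the saturated chain carbon bound to the amide-type nitrogen accounts for these steps, a question that a plain benzyl group or a 3-chlorophenyl group on that nitrogen would address. Also open, going by these compounds, is how the number in this assay would respond to a 4-chlorobenzyl group, a longer chain ending in an amine, or a carboxylic acid at this nitrogen.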